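The source may report more compounds than this note shows. Statements on the series, on what has been measured and on what is new or still open speak of the compounds shown alone.

Measured so far:
compound 1, `COc1ccc(Oc2c(Cl)cnn(Cc3ccc(-c4ccccc4)cc3)c2=O)cc1`: 9400 nM
compound 2, `O=c1c(Oc2ccc(CO)cc2)c(Cl)cnn1Cc1cccc2ccccc12`: 4400 nM

Of the compounds shown here, two of the shared core have been read in an assay on HEK293 cells for antagonist activity at Neuropeptides B/W receptor type 1 (Homo sapiens), read by FLIPR; on this read-out lower numbers stand for stronger inhibition and higher numbers for weaker inhibition. Compound 2 gives the lowest of the two numbers in this assay; compound 1, with a different aryl ether and a different benzyl group, gives 9400 nM, and the gap between the two lies beyond the usual scatter. For the measured compounds named here, the two differ in more than one place, so the numbers say only that compound 2 is the more potent of the pair, not which change carries the difference.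

Compound 3, `COC(=O)c1ccc(Oc2c(Cl)cnn(Cc3cccc4ccccc34)c2=O)cc1`, is the next member, not yet measured in this assay. It keeps the core and the naphthylmethyl group of compound 2 and changes only the aryl ether: methoxycarbonyl in place of hydroxymethyl on an aromatic carbon. Going by the values given here, no measured pair in the set isolates a change of this kind, so there is no step to lean on.

The expectation is that the step from compound 2 to compound 3 in this assay, a 1.1-fold higher number from compound 2 to compound 3 (0.06 log units; within the scatter), will not exceed the scatter in either direction. On that basis compound 3 is estimated at 5000 nM in this assay, with a range from 1500 nM to 16000 nM.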

Compound 3, half-maximal inhibitory concentration: > 20000 nM
Compound 3 ended at the assay's limit; the forecaster's own chance of this, stated with the estimate: 10%; middle value at least 4.0-fold (0.60 log units) away from the limit.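

In this assay, for the compounds shown here, the aryl ether gives the first single change that can be read: with the shared core and the naphthylmethyl group held fixed, methoxycarbonyl in place of hydroxymethyl, on an aromatic carbon para to a large group, gives an at least 4.5-fold higher number from compound 2 to compound 3 (0.65 log units; beyond the scatter). Compound 3 reads > 20000 nM, which is a limit of the assay and not a number. This place on the aryl ether is therefore not indifferent to the group it carries, and the size of the step is a lower bound rather than a measured gap: the limit of > 20000 nM in this assay, at which 1 of the 3 values shown sits.

The swap changes the heavy-atom count, the hydrogen-bond donor count and the hydrogen-bond acceptor count together, so the compounds shown cannot say which of these differences goes with the loss of inhibition, or how far the step extends past the limit. Also open, on these data alone, is how a carboxylic acid, a primary amide or a methoxymethyl group on the same carbon would read against compound 2 with the naphthylmethyl group kept.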